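Carboxymethyl replaces cyclohexylmethyl on the ring nitrogen

This account rests on a few compounds, and the source may have more. Where it says the series, first, only, none or still open, it means among the compounds named here.

The series is followed in a functional assay (trachea) with Cavia porcellus as the target; a lower number here means a stronger inhibitor, a higher number a weaker inhibitor. Compound 1 `Oc1nnc(-c2cccnc2)c2ccccc12` carries nothing on the ring nitrogen, and in this assay compound 1 gives 10200 nM. Going by the values given here, compound 2 `O=c1c2ccccc2c(-c2cccnc2)nn1CC1CCCCC1` carries a cyclohexylmethyl on that nitrogen, and in this assay compound 2 gives 209 nM, the lowest of the three numbers measured so far. Compound 3 `O=c1c2ccccc2c(-c2cccnc2)nn1CCCCSc1ncccn1` carries a longer substituent, and in this assay compound 3 gives 6170 nM. Among the compounds with values here, both compound 1 and compound 3 sit well above compound 2; no pair of measured compounds differs in a single place, so only the values themselves can be set side by side.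

Compound 4 `O=C(O)Cn1nc(-c2cccnc2)c2ccccc2c1=O` is not yet measured. It differs from compound 2 by carboxy in place of cyclohexyl on a saturated chain carbon bound to an aromatic nitrogen. Within the data shown here, nothing among the measured compounds isolates this change. Among the measured compounds shown here, the only guide is that the two compounds lacking the cyclohexylmethyl, compound 1 at 10200 nM and compound 3 at 6170 nM, lie far above compound 2 at 209 nM.

For compound 4 the step of a 24-fold higher number from compound 2 to compound 4 (1.38 log units; beyond the scatter) is expected, a loss well beyond the scatter. In this assay compound 4 is estimated at 5000 nM, with a range from 1000 nM to 25000 nM.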

Compound 4, half-maximal inhibitory concentration: > 100000 nM
Compound 4 ended at the assay's limit (the forecaster's own chance of this, stated with the estimate: 15%); middle value at least 20-fold (1.30 log units) from the limit.
By their numbers in this assay, from the lowest: compound 2; then compounds 3 and 1 (each within the scatter of the next). At a limit, above all of these: compound 4.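

Notes on the ring nitrogen: the swap of cyclohexylmethyl for carboxymethyl is the first change in the series that can be read at a single place, and with an at least 470-fold higher number from compound 2 to compound 4 (2.67 log units; beyond the scatter) in this assay it shows that the outcome at this position depends heavily on what the chain carbon carries, not only on a substituent being present. On these data alone, compound 4 gives > 100000 nM, which is a limit of the assay and not a number, so the true size of the step stays unknown and the printed figure is only a floor. Compound 4 is the one compound in the series that reaches this end of the range: the limit of > 100000 nM in this assay, at which 1 of the 4 values shown sits.

The compounds shown do not separate the effect of the carboxy group entering from that of the cyclohexyl ring leaving, so it remains open whether the loss belongs to either one alone. A methyl ester or a primary amide on the same methylene, or an open-chain hexyl group in place of the cyclohexylmethyl, would bear on that question.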